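Benzylamide for Morpholine Amide on a Longer Ether Chain

This account rests on a few compounds, and the source may have more. Where it says the series, first, only, none or still open, it means among the compounds named here.

Compound 1 `CCCCc1oc2ccccc2c1C(=O)c1ccc(OCC(=O)N2CCOCC2)cc1` gives 34000 nM in a functional assay on MCF7 cells (Homo sapiens) for antiproliferative activity, read by MTT assay, with a stated time of 24 h; on this read-out lower numbers stand for stronger inhibition and higher numbers for weaker inhibition. Compound 2 `CCCCc1oc2ccccc2c1C(=O)c1ccc(OCC(=O)NCc2ccccc2)cc1` differs from it by benzylamino in place of morpholin-4-yl on a carbonyl carbon and gives 19600 nM; the step is a 1.7-fold lower number from compound 1 to compound 2 (0.24 log units; within the scatter). Compound 3 `CCCCc1oc2ccccc2c1C(=O)c1ccc(OCCCC(=O)N2CCOCC2)cc1` gives 41200 nM in this assay; its core differs from that of compound 1 by 2-((morpholin-4-yl)carbonyl)ethyl in place of (morpholin-4-yl)carbonyl on a saturated chain carbon bound to an oxygen on an aromatic ring, and the step is a 1.2-fold higher number from compound 1 to compound 3 (0.08 log units; within the scatter). Compound 4 `CCCCc1oc2ccccc2c1C(=O)c1ccc(OCCCC(=O)NCc2ccccc2)cc1` has not yet been measured and differs from compound 3 by benzylamino in place of morpholin-4-yl on a carbonyl carbon, the same change as that from compound 1 to compound 2, at a place described in the same words. Because a 1.7-fold lower number from compound 1 to compound 2 (0.24 log units; within the scatter) was the outcome of that change, a similar step is expected for compound 4, namely a 1.7-fold lower number from compound 3 to compound 4 (0.23 log units; within the scatter). Compound 4 is therefore estimated at 24000 nM in this assay, with a likely range from 12000 nM to 50000 nM.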

Compound 4, half-maximal inhibitory concentration: 49700 nM
For compound 4 the middle estimate is 2.1-fold (0.32 log units) below the measured one; the range from low to high includes it.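

In this assay, benzylamino in place of morpholin-4-yl on a carbonyl carbon gives a 1.2-fold higher number from compound 3 to compound 4 (0.08 log units; within the scatter). Set beside the earlier step, the same change does not differ measurably between the two cores: the same change on two cores in this assay, a 1.7-fold lower number (0.24 log units; within the scatter) from compound 1 to compound 2 and a 1.2-fold higher number (0.08 log units; within the scatter) from compound 3 to compound 4, 2.1-fold (0.32 log units) apart, within the scatter of two such steps. This shows that the change carries across these two cores without a detectable difference, but each step lies within the scatter, so it does not show that the change has any effect of its own, and two cores say nothing about others.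

The compounds shown leave open whether another amine on the carbonyl, such as piperidine or dimethylamine, or a carboxylic acid in place of the amide, would move the number beyond the scatter. As far as these compounds go, how either amide behaves on a longer chain also remains open.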